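The source may hold more compounds than are shown below. What is called first, only, known or untested is meant among the compounds shown, and "the series" means these compounds.

Measured in an in vitro ADME assay on microsomes from liver (Homo sapiens) for pharmacokinetics, read by LC-MS, with a stated time of 10 min, tested at 1 uM; on this read-out lower numbers stand for slow clearance and higher numbers for fast clearance:
- compound 1 `COc1ccc(NC(=O)[C@H]2CN(C)C[C@@H]2c2ccc(/C=C/C(=O)Nc3ccccc3N)cc2)cc1`: 14 mL/min/kg
- compound 2 `CN1C[C@H](C(=O)Nc2ccc(C3CC3)cc2)[C@@H](c2ccc(/C=C/C(=O)Nc3ccccc3N)cc2)C1`: 12 mL/min/kg

Compound 2, at 12 mL/min/kg, cannot be told apart from compound 1, as the two values lie within the scatter of each other. Compound 3 `CN1C[C@H](C(=O)Nc2ccc(Br)cc2)[C@@H](c2ccc(/C=C/C(=O)Nc3ccccc3N)cc2)C1` has bromo in place of cyclopropyl on an aromatic carbon. Among the measured compounds shown here, the only measured change at this carbon is a 1.2-fold lower number from compound 1 to compound 2 (0.07 log units; within the scatter), which is within the scatter. For the measured compounds named here, one small step is thin evidence, and no bromo compound has been measured yet. The expected change, a 1.1-fold higher number from compound 2 to compound 3 (0.03 log units; within the scatter), therefore stays within the scatter, with no favoured direction. In this assay, the estimated value for compound 3 is 13 mL/min/kg, with an expected range from 7 mL/min/kg to 24 mL/min/kg.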

Compound 3, clearance: 3 mL/min/kg
Beside the measured number, compound 3's estimate is 4.3-fold (0.64 log units) above it; measured number outside the range, below it.
By their numbers in this assay, from the lowest: compound 3; then compounds 2 and 1 (each within the scatter of the next).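

In this assay this carbon proves able to shift clearance: bromo in place of cyclopropyl gives a 4.0-fold lower number from compound 2 to compound 3 (0.60 log units; beyond the scatter) and bromo in place of methoxy gives a 4.7-fold lower number from compound 1 to compound 3 (0.67 log units; beyond the scatter) on the same ring. Among the compounds shown here, the earlier swap between methoxy and cyclopropyl stayed within the scatter, so bromo is the first group here that stands apart from the others. Nothing measured here gives a reason for the drop. On these data alone, whether the low number belongs to bromo alone, or would also come with chloro or fluoro on this carbon, remains open. So does what an amine or a longer chain would give here.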